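This account rests on a few compounds, and the source may have more. Where it says the series, first, only, none or still open, it means among the compounds named here.

Measured compounds:
Compound 1, `O=S(=O)(NCCCCNCc1ccc(Br)cc1)c1cc(C(F)(F)F)cc(C(F)(F)F)c1`: 1500 nM
Compound 2, `O=S(=O)(NCCCNCc1ccc(Cl)c(Cl)c1)c1cc(C(F)(F)F)cc(C(F)(F)F)c1`: 2400 nM
Compound 3, `O=S(=O)(NCCCNCc1ccccc1)c1cc(C(F)(F)F)cc(C(F)(F)F)c1`: 3000 nM

In a functional assay on MCF7 cells (Homo sapiens) for inhibition, read by MTT assay, with a stated time of 72 h (on this read-out lower numbers stand for stronger inhibition of growth and higher numbers for weaker inhibition of growth), compound 2 stands second highest of the three numbers. Its nearest neighbour is compound 3, reached by a 1.3-fold higher number from compound 2 to compound 3 (0.10 log units; within the scatter), and the furthest is compound 1, from which compound 2 is separated by a 1.6-fold higher number from compound 1 to compound 2 (0.20 log units; within the scatter). All three compounds therefore sit within the scatter of one another on this read-out, so none of them can be called the strongest or the weakest.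

Compound 4, `O=S(=O)(NCCCNCc1cccc(Cl)c1)c1cc(C(F)(F)F)cc(C(F)(F)F)c1`, has not yet been measured. It differs from compound 2 by hydrogen in place of chloro on an aromatic carbon. Among the compounds with values here, the steps that bear on this change are those that alter the substitution of the benzyl ring: a 1.3-fold higher number from compound 2 to compound 3 (0.10 log units; within the scatter), where the ring loses both chloro groups, and a 2.0-fold higher number from compound 1 to compound 3 (0.30 log units; within the scatter). Neither step reaches beyond the scatter, and the change from compound 2 to compound 4 removes only one of the two chloro groups, so compound 4 is expected to land between compound 2 and compound 3, with no step beyond the scatter.

The estimated step is a 1.1-fold higher number from compound 2 to compound 4 (0.05 log units; within the scatter). Compound 4 is thus expected to give about 2700 nM in this assay, within a range from 1300 nM to 5500 nM.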

Compound 4, concentration for 50% growth inhibition: 2600 nM
Compound 4: middle estimate off by 1.0-fold (0.02 log units), on the high side; the measured number falls inside the stated range.
By their numbers in this assay, from the lowest: compounds 1, 2, 4 and 3 (each within the scatter of the next).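

In this assay, the chloro group para to a large group can now be read on its own: going from the 3,4-dichlorobenzyl to the 3-chlorobenzyl ring gives a 1.1-fold higher number from compound 2 to compound 4 (0.03 log units; within the scatter), so this single chloro has no readable effect on growth inhibition. Within the data shown here, the remaining chloro can also be read alone for the first time, with a 1.2-fold lower number from compound 3 to compound 4 (0.06 log units; within the scatter), whereas the earlier compounds showed only the two chloro groups together. The 3-chlorobenzyl compound also stays within the scatter of the bromobenzyl compound with its different chain, at a 1.7-fold higher number from compound 1 to compound 4 (0.24 log units; within the scatter), so the flat picture now holds for all four compounds, with none going against it. Nothing available explains this flatness.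

The compounds shown leave open whether a methoxy group, a nitrile or a carboxylic acid at this ring carbon would move the number beyond the scatter, as only hydrogen and chloro have been compared here. They also leave open whether an amide in place of the amine would do so, and the bromo group and the chain of compound 1 cannot be read apart.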